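The source may report more compounds than this note shows. Statements on the series, on what has been measured and on what is new or still open speak of the compounds shown alone.

Compound 1 `Cc1cc(C)nc(SCc2cc(=O)c3cc(Cl)ccc3o2)n1`, compound 2 `O=c1cc(CSc2nc3ccccc3s2)oc2ccc(Cl)cc12` and compound 3 `Cc1ccc2oc(CSc3nc(C)cc(C)n3)cc(=O)c2c1` were examined in a functional assay on HeLa cells (Homo sapiens) for cytotoxicity, read by MTT assay, with a stated time of 72 h; on this read-out lower numbers stand for stronger inhibition and higher numbers for weaker inhibition. In this assay compound 1 gives > 25000 nM, which is a limit of the assay and not a number. Compound 2 likewise gives only a limit, > 25000 nM. Compound 3 also gives a limit, > 25000 nM. The change from compound 1 to compound 3, (methyl in place of chloro on an aromatic carbon), thus gives a step that the two limits leave unreadable from compound 1 to compound 3, as all values sit at the limit of > 25000 nM in this assay, at which 3 of the 3 values shown sit. How the core of compound 1 differs from the core of compound 2 is not broken down here. Compound 4 `Cc1ccc2oc(CSc3nc4ccccc4s3)cc(=O)c2c1`, still unmeasured, carries the same change relative to compound 2: methyl in place of chloro on an aromatic carbon. Beside that unreadable earlier step, the expected step here is a step that the limit leaves unreadable from compound 2 to compound 4, resting on the shared limits. Compound 4 is estimated at 30000 nM, expected between 10000 nM and 100000 nM, most likely again as a limit.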

Compound 4, half-maximal inhibitory concentration: > 25000 nM
Compound 4: no number, only a limit (the forecaster's own chance of this, stated with the estimate: 85%); the middle value does not contradict the limit.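

In this assay compound 4 gives > 25000 nM and this is a limit of the assay and not a number, so no step can be read between compound 2 and compound 4. The compounds shown leave open whether methyl in place of chloro on an aromatic carbon changes the read-out at all: the limit of > 25000 nM in this assay, at which 4 of the 4 values shown sit.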